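Swapping the aryl group for benzyl on the shared core

A few compounds are considered here, and "the series" means these few. Any claim that something is new, unique, unknown or untested is made for them only; others in the source may bear on it.

Measured compounds:
compound 1, `CCOC(=O)c1cnc(-c2cccs2)nc1NN1C(=O)C=C(C)C1=O`, 20 nM
compound 2, `CCOC(=O)c1cnc(-c2cc(Cl)cc(Cl)c2)nc1NN1C(=O)C=C(C)C1=O`, 300 nM

These two compounds share one core and differ only in the group carried on an aromatic carbon between two ring nitrogen atoms. In a functional assay on Jurkat cells for inhibition of nuclear factor NF-kappa-B complex (Homo sapiens) (a higher number here means a weaker inhibitor, a lower number a stronger inhibitor), compound 1 gives 20 nM, while compound 2 gives 300 nM. Going by the values given here, compound 2 therefore stands at the higher of the two numbers, the weaker inhibitor of the pair, and the one step measured so far, a 15-fold higher number from compound 1 to compound 2 (1.18 log units; beyond the scatter), shows that this position responds strongly to what is attached there.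

Compound 3, `CCOC(=O)c1cnc(Cc2ccccc2)nc1NN1C(=O)C=C(C)C1=O`, carries the change (benzyl in place of 3,5-dichlorophenyl on an aromatic carbon). Among the compounds with values here, no measured pair shows a benzyl at this position, so the only guide is that the step from compound 1 to compound 2 was large, which means a sizeable move in either direction is plausible. With nothing pointing one way, the estimate for compound 3 in this assay is placed near compound 2, at 250 nM, expected to lie between 50 nM and 1500 nM, which corresponds to an expected step of a 1.2-fold lower number from compound 2 to compound 3 (0.08 log units; within the scatter).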

Compound 3, half-maximal inhibitory concentration: 7000 nM
Compound 3: the middle estimate sits 28-fold (1.45 log units) below what was measured; the measured number lies above the stated range.
By their numbers in this assay, from the lowest: compound 1; then compound 2; then compound 3.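

In this assay, replacing 3,5-dichlorophenyl with benzyl gives a 23-fold higher number from compound 2 to compound 3 (1.37 log units; beyond the scatter), and the full range seen at this position now reaches a 350-fold higher number from compound 1 to compound 3 (2.54 log units; beyond the scatter). Both groups contain one six-membered aromatic ring of carbon only and neither has a hydrogen-bond donor or acceptor, so these shared features alone do not keep the number low: in benzyl the ring stands one carbon further from the shared core, and this compound is the weakest inhibitor of the three. Nothing available here explains why the number climbs so far with this change.

The three compounds do not separate the extra carbon of benzyl from the missing chlorine atoms. A plain phenyl group on the same core, which would help separate the two, is not among those shown. They also leave open whether another five-membered aromatic ring, such as furan-2-yl, would stay close to the thiophen-2-yl of compound 1, and how an amine or a longer chain ending in phenyl would fare at this position.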